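Series notes: from compound 3 to compound 4

The compounds below may be only part of what the source reports. "The series", "measured", "known", "first", "only" and "open" are said of these compounds alone.

Measured so far:
- compound 1, `COc1cc2ccc(=O)oc2cc1OCCOc1no[n+]([O-])c1S(=O)(=O)c1ccccc1`: in a functional assay on HepG2 cells (Homo sapiens) for inhibition, read by MTT assay, with a stated time of 48 h (on this read-out lower numbers stand for stronger inhibition and higher numbers for weaker inhibition), compound 1 gives 3610 nM
- compound 2, `COc1cc2ccc(=O)oc2cc1OCCCCCOc1c[n+]([O-])on1`: in this assay compound 2 gives 3420 nM
- compound 3, `COc1cc2cc(NC(C)=O)c(=O)oc2cc1OCCOc1no[n+]([O-])c1S(=O)(=O)c1ccccc1`: in this assay compound 3 gives 4830 nM

Compound 3 carries the highest of the three numbers, but the gaps are small: the step of a 1.3-fold higher number from compound 1 to compound 3 (0.13 log units; within the scatter) lies within the scatter, and the values of compound 2 and compound 3 sit close enough together that nothing separates them either. On the numbers shown the three compounds cannot be told apart.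

Compound 4, `COc1cc2cc(N)c(=O)oc2cc1OCCOc1no[n+]([O-])c1S(=O)(=O)c1ccccc1`, differs from compound 3 by hydrogen in place of acetyl on a nitrogen on an aromatic ring; cut one bond further out, the change reads acetamido to amino. Among the measured compounds shown here, the only measured step touching this position is a 1.3-fold higher number from compound 1 to compound 3 (0.13 log units; within the scatter), where putting the acetamido group onto the ring carbon in place of hydrogen left the number within the scatter. For the measured compounds named here, no measured step removes the acetyl from the nitrogen while keeping the amino group, so the expectation for compound 4 rests on that one step alone.

Since compound 1 and compound 3 are separated only by a 1.3-fold higher number from compound 1 to compound 3 (0.13 log units; within the scatter), the step of a 1.2-fold lower number from compound 3 to compound 4 (0.08 log units; within the scatter) is expected to stay within the scatter. Compound 4 is therefore estimated at 4000 nM, with a range from 1500 nM to 11000 nM.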

Compound 4, half-maximal inhibitory concentration: 3060 nM
Beside the measured number, compound 4's estimate is 1.3-fold (0.12 log units) above it, and the stated range covers the measured number.
By their numbers in this assay, from the lowest: compounds 4, 2, 1 and 3 (each within the scatter of the next).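

In this assay the free amino group adds a third substituent at this ring position, and neither new step leaves the scatter: removing the acetyl from the nitrogen gives a 1.6-fold lower number from compound 3 to compound 4 (0.20 log units; within the scatter) and amino in place of hydrogen on the aromatic carbon gives a 1.2-fold lower number from compound 1 to compound 4 (0.07 log units; within the scatter) in the same read-out. Earlier, only the acetamido step could be read here, whereas hydrogen, acetamido and amino can now be compared directly, and compound 1, compound 3 and compound 4 all stay within the scatter of one another. No supporting data are available to explain this flat result.

As far as these compounds go, whether a larger acyl group on that nitrogen, such as benzoyl, or a different group on the same aromatic carbon, such as a carboxylic acid or a nitrile, would move the number beyond the scatter remains open. Also open, from the compounds shown here alone, is whether amino and acetamido would still read alike with a longer chain joining the shared core to the sulfonyl-bearing ring.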